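A few compounds are considered here, and "the series" means these few. Any claim that something is new, unique, unknown or untested is made for them only; others in the source may bear on it.

Measured compounds:
Compound 1, `CN(C)c1ccc(C(=O)N(CC(=O)NCc2ccccc2)Cc2ccc(C(=O)Nc3cc(-c4ccccc4)ccc3N)cc2)cc1`, in an assay on Sf9 cells for inhibition of protein deacetylase HDAC6 (Homo sapiens), read by fluorescence, with a stated time of 90 min (on this read-out lower numbers stand for stronger inhibition and higher numbers for weaker inhibition), gives only a limit, > 10000 nM.
Compound 2, `CN(C)c1ccc(C(=O)N(CC(=O)NCc2ccccc2)Cc2ccc(C(=O)Nc3ccccc3N)cc2)cc1`, in this assay gives only a limit, > 10000 nM.

Compound 2 therefore has no number of its own, only a limit; where it stands is told by the limit of > 10000 nM in this assay, at which 2 of the 2 values shown sit. Among the measured compounds shown here, the single measured step, a step that the two limits leave unreadable from compound 1 to compound 2, joins two limits and so cannot be read in size, and it touches a different part of the molecule in any case. Compound 3, `Nc1ccccc1NC(=O)c1ccc(CN(CC(=O)NCc2ccccc2)C(=O)c2cccnc2)cc1`, differs from compound 2 by pyridin-3-yl in place of 4-(dimethylamino)phenyl on a carbonyl carbon. No measured step bears on this change, so nothing shown points in either direction. With both known values sitting at the limit, compound 3 is expected to stay weak as well, most likely again reported as a limit. Compound 3 is estimated at 15000 nM, within a range from 5000 nM to 50000 nM. The expected step is a step that the limit leaves unreadable from compound 2 to compound 3, that is, no change readable beyond the scatter.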

Compound 3, half-maximal inhibitory concentration: > 10000 nM
Compound 3: no number, only a limit; the forecaster's own chance of this, stated with the estimate: 80%; the middle value is on the limit's open side.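

Compound 3, like compound 2, is reported only as a limit, and the step between compound 2 and compound 3 cannot be read in size. How strongly any of these compounds inhibits in this assay, and whether pyridin-3-yl or 4-(dimethylamino)phenyl gives the stronger inhibition, stays open.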